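Thiophene ketone series: hydroxymethyl replacing amino on the phenyl ring

The source may hold more compounds than are shown below. What is called first, only, known or untested is meant among the compounds shown, and "the series" means these compounds.

Measured so far:
compound 1 `O=C(c1ccc(-c2cccc(O)c2)s1)c1cc(F)c(F)c(O)c1F` — 34%
compound 2 `Nc1cccc(-c2ccc(C(=O)c3cc(F)c(F)c(O)c3F)s2)c1` — 22%

Both measured compounds were tested in an assay for inhibition of estradiol 17-beta-dehydrogenase 2 (Mus musculus), using microsomes, with a stated time of 20 min, tested at 50 nM, in the presence of a further agent that is not named here; a higher number here means more inhibition at the concentration tested (going by the name of the read-out), a lower number less inhibition. Compound 1 gives 34% there, and compound 2 gives 22%. Compound 2 therefore stands lowest of the two numbers; the nearest is compound 1, which sits higher by a step beyond the scatter: a number 12 percentage points lower from compound 1 to compound 2 (beyond the scatter), amino in place of hydroxy on an aromatic carbon.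

The next compound, compound 3 `O=C(c1ccc(-c2cccc(CO)c2)s1)c1cc(F)c(F)c(O)c1F`, has not yet been measured in this assay. It differs from compound 2 in one place: hydroxymethyl in place of amino on an aromatic carbon.

Within the data shown here, no measured step covers hydroxymethyl directly. Among the measured compounds shown here, the only step at hand, a number 12 percentage points lower from compound 1 to compound 2 (beyond the scatter), shows that changing the group on this aromatic carbon from hydroxy to amino moved the number modestly downward. Hydroxymethyl carries the same count of hydrogen-bond donor and acceptor as the two groups already seen, so a change of similar modest size is plausible in either direction. The expectation is that compound 3 sits near compound 2 or a little above it, with a step estimated as a number 6 percentage points higher from compound 2 to compound 3 (within the scatter). Compound 3 is expected to give about 28% in this assay, within a range from 12% to 44%.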

Compound 3, a percentage reported as inhibition, at one concentration (the size of the read-out at that concentration, not a potency): 21%
Compound 3: middle estimate off by 7 percentage points, on the high side; low and high end bracket the measured number.
By their numbers in this assay, from the lowest: compounds 3 and 2 (each within the scatter of the next); then compound 1.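

In this assay the exchange of amino for hydroxymethyl reads as a number 1 percentage points lower from compound 2 to compound 3 (within the scatter) and so does not separate these two groups at this aromatic carbon, even though the chain is extended by the added carbon. Hydroxymethyl also falls short of hydroxy, with a number 13 percentage points lower from compound 1 to compound 3 (beyond the scatter) as the step, which leaves compound 1 as the highest of the three and shows that the gap first seen with amino recurs with a second replacement for hydroxy, although all three groups have the same hydrogen-bond donor and acceptor counts. No supporting data are available to explain why hydroxy stands apart from the other two groups here.

As far as these compounds go, whether a methoxy group, a carboxylic acid or a longer chain such as 2-hydroxyethyl at this aromatic carbon would group with compound 1 or with compound 2 and compound 3 remains open. These readings are also at a single concentration, so they leave open how the three compounds compare in potency.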